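Aryl variation on the aromatic nitrogen of a shared core

The source may hold more compounds than are shown below. What is called first, only, known or untested is meant among the compounds shown, and "the series" means these compounds.

Three measured compounds share one core and differ only in the aryl group on a nitrogen on an aromatic ring. Compound 1 `COc1cc2ncnc(Nc3ccc(F)c(Cl)c3)c2cc1OCCCCC(=O)Nc1ccc(S(N)(=O)=O)cc1` carries 3-chloro-4-fluorophenyl there; in a functional assay on A-431 cells (Homo sapiens) for antiproliferative activity, read by MTT assay, with a stated time of 72 h (on this read-out lower numbers stand for stronger inhibition and higher numbers for weaker inhibition), compound 1 gives 5020 nM. Compound 2 `COc1cc2ncnc(Nc3ccc(Cl)c(C(F)(F)F)c3)c2cc1OCCCCC(=O)Nc1ccc(S(N)(=O)=O)cc1` carries 4-chloro-3-(trifluoromethyl)phenyl, and in this assay compound 2 gives 3910 nM. Compound 3 `COc1cc2ncnc(Nc3cccc(C)c3)c2cc1OCCCCC(=O)Nc1ccc(S(N)(=O)=O)cc1` carries 3-methylphenyl, and in this assay compound 3 gives 7460 nM. Among these three numbers compound 1 stands second highest; the three steps, a 1.3-fold lower number from compound 1 to compound 2 (0.11 log units; within the scatter), a 1.5-fold higher number from compound 1 to compound 3 (0.17 log units; within the scatter) and a 1.9-fold higher number from compound 2 to compound 3 (0.28 log units; within the scatter), all lie within the scatter, so no order can be drawn among the three compounds.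

Compound 4 `COc1ccccc1Nc1ncnc2cc(OC)c(OCCCCC(=O)Nc3ccc(S(N)(=O)=O)cc3)cc12` has not been measured. It differs from compound 1 as follows: 2-methoxyphenyl in place of 3-chloro-4-fluorophenyl on a nitrogen on an aromatic ring. All three measured steps concern this same position, and none of them moved the number beyond the scatter, though none of them places a group resembling the entering one there, so the spread of possible outcomes is wider than the measured steps alone suggest. Compound 4 is therefore expected to land near compound 1, with a 1.2-fold higher number from compound 1 to compound 4 (0.08 log units; within the scatter) estimated as a step of no clear direction. For compound 4 the expected value in this assay is 6000 nM, with a range from 2500 nM to 15000 nM.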

Compound 4, half-maximal inhibitory concentration: 24200 nM
The estimate for compound 4 lay 4.0-fold (0.61 log units) below the measured number; measured number above the stated range.
By their numbers in this assay, from the lowest: compounds 2, 1 and 3 (each within the scatter of the next); then compound 4.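

In this assay, among the compounds shown here, this position proves sensitive to the aryl group: 2-methoxyphenyl on the nitrogen gives a 4.8-fold higher number from compound 1 to compound 4 (0.68 log units; beyond the scatter) and a 3.2-fold higher number from compound 3 to compound 4 (0.51 log units; beyond the scatter) and a 6.2-fold higher number from compound 2 to compound 4 (0.79 log units; beyond the scatter) in the first steps here to lie beyond the scatter. The near-equal numbers of compounds 1, 2 and 3 therefore describe only those three aryl groups, not a general tolerance at this position, and compound 4 is the weakest of the four, with one hydrogen-bond acceptor on its entering group where 3-chloro-4-fluorophenyl has none. No measurement shown explains why this change raises the number.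

For the compounds shown here, with only one methoxy-bearing aryl group in the set, the effect of the methoxy group cannot be separated from that of its place on the ring. Also open, from the compounds shown here alone, is how the number would respond to an aryl group carrying an amine or a carboxylic acid, or to a longer chain in place of the methoxy group.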